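This account rests on a few compounds, and the source may have more. Where it says the series, first, only, none or still open, it means among the compounds named here.

Measured compounds in a functional assay on MIA PaCa-2 cells (Homo sapiens) for inhibition, read by MTT assay, with a stated time of 3 days; a higher number here means a weaker inhibitor, a lower number a stronger inhibitor:
Compound 1 `O=C([C@@H]1CCCN(S(=O)(=O)c2ccc(S(=O)(=O)C3CCC3)cc2)C1)N1CCC(F)(F)CC1`: > 3000 nM, a limit of the assay.
Compound 2 `CCN(CC)S(=O)(=O)c1ccc(S(=O)(=O)N2CCC[C@@H](C(=O)N3CCC(OC)CC3)C2)cc1`: > 10000 nM, a limit of the assay.
Compound 3 `CC(C)S(=O)(=O)c1ccc(S(=O)(=O)N2CCC[C@@H](C(=O)N3CCC(F)(F)CC3)C2)cc1`: > 3000 nM, a limit of the assay.

Among the compounds with values here, compound 2 gives only a limit in this assay and is the single value sitting at the limit of > 10000 nM in this assay, at which 1 of the 3 values shown sits. The remaining two values sit at the limit of > 3000 nM in this assay, at which 2 of the 3 values shown sit. Within the data shown here, the sole measured step, a step that the two limits leave unreadable from compound 1 to compound 3, runs between two limits, so its size cannot be read. Compound 4 `CCN(CC)S(=O)(=O)c1ccc(S(=O)(=O)N2CCC[C@@H](C(=O)N3CCC(C(F)(F)F)CC3)C2)cc1` differs from compound 2 by trifluoromethyl in place of methoxy on a saturated ring carbon. Among the measured compounds shown here, no measured step touches this position, and no measured step gives a readable size at all. No direction or size beyond the scatter can therefore be expected. The expected step is a number no higher from compound 2 to compound 4 (the limit leaves the size open). Compound 4 is expected at 10000 nM in this assay, with a range from 3000 nM to 30000 nM, most likely again reported only as a limit.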

Compound 4, half-maximal inhibitory concentration: > 10000 nM
Compound 4: no number, only a limit; the forecaster's own chance of this, stated with the estimate: 80%; the middle value lies on the limit itself.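

No new step can be read: compound 2 and compound 4 each give only a limit of the assay, so trifluoromethyl in place of methoxy has no readable size. The compounds shown leave open which change, if any, yields an actual number in this assay.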